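Working notes: ring group on the aromatic nitrogen

This account rests on a few compounds, and the source may have more. Where it says the series, first, only, none or still open, it means among the compounds named here.

Measured so far:
compound 1 `COCCn1nc(C(=O)N[C@H]2COc3ccccc3N(C)C2=S)nc1Cc1ccccc1` — in a functional assay on HT-29 cells (Homo sapiens) for inhibition, read by luminescence and CellTiter-Glo, with a stated time of 24 h (on this read-out lower numbers stand for an effect already at smaller amounts and higher numbers for an effect only at larger amounts of compound), compound 1 gives 566 nM
compound 2 `CN1C(=S)[C@@H](NC(=O)c2nc(Cc3ccccc3)n(C3CCC3)n2)COc2ccccc21` — in this assay compound 2 gives 181 nM

Going by the values given here, compound 2 holds the lowest of the two numbers; the step of a 3.1-fold lower number from compound 1 to compound 2 (0.50 log units; beyond the scatter) separates it from compound 1, the only other compound measured. Compound 3 `CN1C(=S)[C@@H](NC(=O)c2nc(Cc3ccccc3)n(C3CCNC3)n2)COc2ccccc21` is not yet measured. It differs from compound 2 in one place: pyrrolidin-3-yl in place of cyclobutyl on an aromatic nitrogen.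

Among the compounds with values here, no measured step exchanges a ring of carbon only for a ring with a hetero atom on this aromatic nitrogen. Within the data shown here, the single step in hand, a 3.1-fold lower number from compound 1 to compound 2 (0.50 log units; beyond the scatter), concerns a different exchange on the same aromatic nitrogen and shows only that changes there can move the number by a modest amount. Among the measured compounds shown here, with no direct precedent, compound 3 is expected to remain near compound 2, and the step of a 1.4-fold higher number from compound 2 to compound 3 (0.14 log units; within the scatter) is expected to lie within or close to the scatter. The estimate for compound 3 in this assay is 250 nM, with an expected range from 80 nM to 800 nM.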

Compound 3, half-maximal effective concentration: 1070 nM
Compound 3: middle estimate off by 4.3-fold (0.63 log units), on the low side, outside the stated range (above it).
By their numbers in this assay, from the lowest: compound 2; then compounds 1 and 3 (each within the scatter of the next).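

In this assay, going by these compounds alone, the step of a 5.9-fold higher number from compound 2 to compound 3 (0.77 log units; beyond the scatter) is the first measured exchange of a ring of carbon only for a ring with a hetero atom on this aromatic nitrogen, and it shows that the position does not accept every ring group alike. The advantage of cyclobutyl over 2-methoxyethyl does not carry over to pyrrolidin-3-yl: the step of a 1.9-fold higher number from compound 1 to compound 3 (0.28 log units; within the scatter) leaves the ring with a nitrogen and the open chain with no separable difference. Among the three groups, cyclobutyl alone stands apart, with printed steps beyond the scatter to both others. Nothing in hand explains this difference.

The step from cyclobutyl to pyrrolidin-3-yl changes both ring size and ring composition, so the compounds shown cannot assign the higher number to either change. Cyclopentyl would keep the five-membered ring with carbon only, while tetrahydrofuran-3-yl and 1-methylpyrrolidin-3-yl would replace the ring nitrogen and its hydrogen, and these groups could separate the two changes.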